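The source may report more compounds than this note shows. Statements on the series, on what has been measured and on what is new or still open speak of the compounds shown alone.

Measured so far in a functional assay on L1210 cells (Mus musculus) for cytotoxicity; on this read-out lower numbers stand for stronger inhibition and higher numbers for weaker inhibition:
- compound 1 `C=C[C@]1(CO)O[C@@H](n2ccc(N)nc2=O)C[C@@H]1O` gives 21000 nM here
- compound 2 `N#C[C@]1(CO)O[C@@H](n2ccc(N)nc2=O)C[C@@H]1O` gives 330 nM here

Compound 2 has the lower of the two numbers. Among the measured compounds shown here, the only measured step is a 64-fold lower number from compound 1 to compound 2 (1.80 log units; beyond the scatter), made at the same place as the next change.

That change leads to compound 3 `CC[C@]1(CO)O[C@@H](n2ccc(N)nc2=O)C[C@@H]1O`, with ethyl in place of cyano on a saturated ring carbon. Ethyl, like the vinyl of compound 1, holds only carbon and hydrogen, and the nitrile of compound 2 is gone. No saturated group has been measured at this place, so compound 1 at 21000 nM is the closest guide, and one step is thin support. A large move to a higher number is therefore expected in this assay, of about the size of a 64-fold lower number from compound 1 to compound 2 (1.80 log units; beyond the scatter) read in reverse. The expected change is a 76-fold higher number from compound 2 to compound 3 (1.88 log units; beyond the scatter), and this remains an estimate. For compound 3 the estimated value is 25000 nM, with an expected range from 6000 nM to 100000 nM.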

Compound 3, half-maximal inhibitory concentration: 55000 nM
For compound 3 the middle estimate is 2.2-fold (0.34 log units) below the measured one, within the range that was stated.
By their numbers in this assay, from the lowest: compound 2; then compound 1; then compound 3.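

In this assay, the change from cyano to ethyl on this saturated ring carbon, next to the ring oxygen, gives a 170-fold higher number from compound 2 to compound 3 (2.22 log units; beyond the scatter), so the large step first seen with vinyl also appears with a saturated group of the same heavy-atom count as cyano. Ethyl in place of vinyl gives only a 2.6-fold higher number from compound 1 to compound 3 (0.42 log units; beyond the scatter), a real but much smaller step, which leaves the two groups made solely of carbon and hydrogen close together in this assay and far from the nitrile of compound 2 at this position. The data offer no measurement that accounts for this gap between the nitrile and the two hydrocarbon groups.

Among the compounds shown here, with only three groups at this carbon, the low number of compound 2 could belong to the nitrile specifically or be shared by other small groups. Ethynyl would separate the triple bond from the nitrogen, while an aminomethyl group, a carboxylic acid or a longer chain such as propyl would show how far the position tolerates other atoms and greater length.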